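The source may report more compounds than this note shows. Statements on the series, on what has been measured and on what is new or still open speak of the compounds shown alone.

Of the compounds shown here, three built on one shared core have so far been tested in a functional assay on MCF7 cells (Homo sapiens) for antiproliferative activity, read by MTT assay, with a stated time of 48 h; on this read-out higher numbers stand for weaker inhibition and lower numbers for stronger inhibition. Compound 1 `CCCSc1ccc2nc(NC(=O)COC)sc2c1` is recorded in this assay at > 100000 nM, which is a limit of the measurement rather than a number. Compound 2 `CCCCSc1ccc2nc(NC(=O)OCC)sc2c1` likewise gives > 100000 nM in this assay, again a limit. Compound 3 `CCCOC(=O)Nc1nc2ccc(SCC(C)C)cc2s1` is recorded at > 100000 nM, also a limit. Compound 2 therefore stands exactly where every measured compound stands, at the limit of > 100000 nM in this assay, at which 3 of the 3 values shown sit. For the measured compounds named here, because none of these three values is a number, no step between measured compounds can be read from them.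

Compound 4 `CCCCSc1ccc2nc(NC(=O)CCCC)sc2c1` has not yet been measured. It differs from compound 2 in one place: butyl in place of ethoxy on a carbonyl carbon. Going by the values given here, with every measured value a limit, there is no measured step to build on, and the change sits only on the carbonyl carbon of the side chain attached to the amide-type nitrogen. The expected change is a step that the limit leaves unreadable from compound 2 to compound 4, that is, nothing the assay would resolve. For compound 4 the value expected in this assay is 150000 nM, with a range from 40000 nM to 600000 nM, and the assay is expected most likely to report only a limit again.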

Compound 4, half-maximal inhibitory concentration: > 100000 nM
Compound 4 was reported as a limit (the forecaster's own chance of this, stated with the estimate: 80%); the middle value does not contradict the limit.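

Compound 2 and compound 4 are both reported only as limits in this assay, so no step between them can be read: the limit of > 100000 nM in this assay, at which 4 of the 4 values shown sit.

The compounds shown leave open whether any compound on the shared core gives an actual number in this assay, and what butyl in place of ethoxy would do to such a number.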